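The compounds below may be only part of what the source reports. "The series", "measured", "known", "first", "only" and "open" are said of these compounds alone.

Compound 1 `CC(C)NC(=O)CC(c1ccc(-c2ccc3cccc(F)c3c2)[nH]c1=O)C(C)C` gives 5.8 nM in an assay on CHO cells for displacement of a labelled ligand from prostaglandin E2 receptor EP3 subtype (Homo sapiens), read by radioligand binding; on this read-out lower numbers stand for stronger inhibition and higher numbers for weaker inhibition; compound 2 `CC(C)C(c1ccc(-c2ccc3cccc(F)c3c2)[nH]c1=O)N1CCNC1=O` gives 9.1 nM; compound 3 `CC(C)C(c1ccc(-c2ccc3cccc(F)c3c2)[nH]c1=O)N1CCN/C1=N\C#N` gives 23 nM.

Compound 3 thus carries the highest number of the three: the step of a 2.5-fold higher number from compound 2 to compound 3 (0.40 log units; beyond the scatter) and the step of a 4.0-fold higher number from compound 1 to compound 3 (0.60 log units; beyond the scatter) both lie beyond the scatter, while a 1.6-fold higher number from compound 1 to compound 2 (0.20 log units; within the scatter) does not. Compound 4 `CC(C)C(/C=C1/CCNC1=O)c1ccc(-c2ccc3cccc(F)c3c2)[nH]c1=O` differs from compound 3 in one place: a group of 7 heavy atoms (5 carbon, 1 nitrogen, 1 oxygen; one five-membered non-aromatic ring with 1 hetero atom) in place of a group of 8 heavy atoms (4 carbon, 4 nitrogen; one five-membered non-aromatic ring with 2 hetero atoms), on a saturated chain carbon bound to an aromatic carbon and a saturated chain carbon. Both measured steps into compound 3 show that the entering cyanoimino-bearing ring raised the number, so undoing it for a group that, like those of compound 1 and compound 2, holds a single carbonyl is expected to lower the number again, by about a 2.9-fold lower number from compound 3 to compound 4 (0.46 log units; beyond the scatter). Compound 4 is therefore estimated at 8 nM, within 3 nM to 25 nM.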

Compound 4, inhibition constant: 5.3 nM
Beside the measured number, compound 4's estimate is 1.5-fold (0.18 log units) above it; the measured number falls inside the stated range.
By their numbers in this assay, from the lowest: compounds 4, 1 and 2 (each within the scatter of the next); then compound 3.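

In this assay, exchanging the cyanoimino-bearing ring for a group with a five-membered non-aromatic ring with 1 hetero atom gives a step beyond the scatter (a 4.3-fold lower number from compound 3 to compound 4 (0.64 log units; beyond the scatter)). The other two comparisons (a 1.7-fold lower number from compound 2 to compound 4 (0.23 log units; within the scatter)) and (a 1.1-fold lower number from compound 1 to compound 4 (0.04 log units; within the scatter)) lie within the scatter, so this new ring stands level with both the open chain and the ring with 2 hetero atoms at this saturated chain carbon. Nothing available explains these numbers.

The compounds shown leave open how a carboxylic acid or an amine would fare on this carbon. They also leave open whether a six-membered ring would hold the number.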